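Methyl in Place of Hydrogen on the Outer Phenyl

The source may report more compounds than this note shows. Statements on the series, on what has been measured and on what is new or still open speak of the compounds shown alone.

Of the compounds shown here, three sharing one core have been tested in a functional assay on T-24 cells (Homo sapiens) for antiproliferative activity, read by MTT assay, with a stated time of 48 h; a lower number here means a stronger inhibitor, a higher number a weaker inhibitor. Compound 1 `O=C(Nc1ccccc1)Nc1cccc(CNc2nccnc2Cl)c1` gives 19800 nM and stands second highest of the three numbers, with compound 2 `O=C(Nc1cccc(CNc2nccnc2Cl)c1)Nc1ccc(F)c(Cl)c1` at 4990 nM and compound 3 `CS(=O)(=O)c1ccc(NC(=O)Nc2cccc(CNc3nccnc3Cl)c2)cc1` at 29300 nM. Compound 4 `Cc1ccc(NC(=O)Nc2cccc(CNc3nccnc3Cl)c2)cc1` differs from compound 1 in one place: methyl in place of hydrogen on an aromatic carbon. Going by the values given here, two measured steps bear on changes at this outer ring. Swapping in a 3-chloro-4-fluorophenyl gave a 4.0-fold lower number from compound 1 to compound 2 (0.60 log units; beyond the scatter), while adding a methylsulfonyl gave a 1.5-fold higher number from compound 1 to compound 3 (0.17 log units; within the scatter). A single methyl is a smaller change than either, so only a small step is expected, perhaps slightly toward a lower number, a 1.4-fold lower number from compound 1 to compound 4 (0.15 log units; within the scatter). Compound 4 is therefore estimated at 14000 nM, within 5000 nM to 40000 nM.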

Compound 4, half-maximal inhibitory concentration: 9820 nM
Compound 4: the middle estimate sits 1.4-fold (0.15 log units) above what was measured, and the stated range covers the measured number.
By their numbers in this assay, from the lowest: compounds 2, 4, 1 and 3 (each within the scatter of the next, the first and the last beyond it).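

Methyl on this carbon, para to a large group, moves the number only within the scatter, with a 2.0-fold lower number from compound 1 to compound 4 (0.30 log units; within the scatter). The same place does respond to what sits there, however: methyl in place of methylsulfonyl gives a 3.0-fold lower number from compound 3 to compound 4 (0.47 log units; beyond the scatter). The 4-methylphenyl cannot be told apart from the 3-chloro-4-fluorophenyl, with a 2.0-fold higher number from compound 2 to compound 4 (0.29 log units; within the scatter).

No measured evidence explains these steps. Still open, going by these compounds, is how an amine, a carboxylic acid or a longer chain on this same carbon would compare.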